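Extending a Fluorinated Chain on a Shared Core

The source may report more compounds than this note shows. Statements on the series, on what has been measured and on what is new or still open speak of the compounds shown alone.

Compound 1 `FC(F)(F)C(F)(F)C(F)(F)C(F)(F)C(F)(F)C(F)(F)CCn1cc(COc2ccccc2-c2nc3ccccc3s2)nn1`: 14200 nM
Compound 2 `FC(F)(F)c1cccc(-n2cc(COc3ccccc3-c3nc4ccccc4s3)nn2)c1`: 10800 nM

Both compounds were tested in a functional assay on COLO 205 cells (Homo sapiens) for cytotoxicity, read by MTT assay, with a stated time of 24 h; a lower number here means a stronger inhibitor, a higher number a weaker inhibitor. Compound 1 gives 14200 nM, and compound 2 gives 10800 nM; the two numbers lie within the scatter of repeated measurements, so neither can be called the stronger or weaker inhibitor, and both are weak.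

Compound 3 `FC(F)(F)C(F)(F)C(F)(F)C(F)(F)C(F)(F)C(F)(F)C(F)(F)C(F)(F)CCn1cc(COc2ccccc2-c2nc3ccccc3s2)nn1` keeps everything in compound 1 except for one change, (1,1,2,2,2-pentafluoroethyl in place of fluoro on a saturated chain carbon bound to two fluorine atoms and a saturated chain carbon), which makes the fluorinated chain longer. Within the data shown here, no two measured compounds differ in a single place, so no step of this kind has been measured here. Since compound 1 is already weak, little movement is expected: a step from compound 1 to compound 3 of a 1.1-fold higher number from compound 1 to compound 3 (0.05 log units; within the scatter) is expected, not beyond the scatter. Compound 3 is estimated at 16000 nM in this assay, with a range from 5000 nM to 50000 nM.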

Compound 3, half-maximal inhibitory concentration: 12200 nM
For compound 3 the middle estimate is 1.3-fold (0.12 log units) above the measured one; low and high end bracket the measured number.
By their numbers in this assay, from the lowest: compounds 2, 3 and 1 (each within the scatter of the next).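

In this assay, 1,1,2,2,2-pentafluoroethyl in place of fluoro on a saturated chain carbon bound to two fluorine atoms and a saturated chain carbon gives a 1.2-fold lower number from compound 1 to compound 3 (0.07 log units; within the scatter) and so the two chain lengths cannot be told apart. Among these compounds, this is the first comparison here of two compounds that differ in one place, and it shows that this extension of the fluorinated chain leaves the reading where the scatter cannot separate it from that of compound 1. No supporting measurement here bears on this result.

The compounds shown leave open whether a chain that ends in something other than fluorine, such as an amine or a carboxylic acid, would give a clearly different number. They also leave open how a plain hydrocarbon chain would compare with these fluorinated chains on the same shared core.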